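Amine swap on the butoxy chain of compound 1

This account rests on a few compounds, and the source may have more. Where it says the series, first, only, none or still open, it means among the compounds named here.

Compound 1 `CN1CCN(CCCCOc2c(O)cc3oc(-c4ccccc4)cc(=O)c3c2O)CC1` gives 93700 nM in a functional assay on HepG2 cells (Homo sapiens) for antiproliferative activity, read by MTT assay, with a stated time of 48 h (on this read-out lower numbers stand for stronger inhibition and higher numbers for weaker inhibition), the highest of the two numbers in hand. Compound 2 `CN1CCN(CCCCOc2c(OCc3ccccc3)cc3oc(-c4ccccc4)cc(=O)c3c2O)CC1` gives 2500 nM; that step, a 37-fold lower number from compound 1 to compound 2 (1.57 log units; beyond the scatter), concerns the benzyl on the ring oxygen and not the amine. Compound 3 `O=c1cc(-c2ccccc2)oc2cc(O)c(OCCCCN3CCCCC3)c(O)c12` keeps the free hydroxyl of compound 1 and differs only at the chain end: piperidin-1-yl in place of 4-methylpiperazin-1-yl on a saturated chain carbon, four bonds along the chain from an oxygen on an aromatic ring. Going by the values given here, no measured pair tests this change, so nothing here anchors it; the expectation is a step of a 1.3-fold lower number from compound 1 to compound 3 (0.13 log units; within the scatter), within the scatter. Compound 3 is estimated at 70000 nM, range 20000 nM to 200000 nM.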

Compound 3, half-maximal inhibitory concentration: > 100000 nM
Compound 3 ended at the assay's limit; the forecaster's own chance of this, stated with the estimate: 25%; middle value at least 1.4-fold (0.15 log units) from the limit.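

In this assay compound 3 gives > 100000 nM, a limit of the assay and not a number. Going by these compounds alone, this is the first reading of a change in the amine on the butoxy chain: piperidin-1-yl in place of 4-methylpiperazin-1-yl gives an at least 1.0-fold higher number from compound 1 to compound 3 (0.02 log units; that floor lies within the scatter). Only a floor is known for this step, and its true size stays unfixed: the limit of > 100000 nM in this assay, at which 1 of the 3 values shown sits.

From the compounds shown here alone, whether the same swap would read differently with the benzyl of compound 2 present stays open. Also open, going by these compounds, are morpholine or dimethylamino in place of either amine, and a longer chain.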